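The source may report more compounds than this note shows. Statements on the series, on what has been measured and on what is new or still open speak of the compounds shown alone.

Measured compounds:
Compound 1 `O=S(=O)(Nc1ccc(-c2nc3ccccc3o2)cc1)c1ccc(Cl)c(C(F)(F)F)c1`, in an assay on cells for inhibition of HSP60/HSP10 (Homo sapiens), with a stated time of 60 min (a higher number here means a weaker inhibitor, a lower number a stronger inhibitor), compound 1 gives 12000 nM.
Compound 2 `O=S(=O)(Nc1ccc(-c2nc3ccccc3o2)cc1)c1ccc(Cl)s1`, in this assay compound 2 gives 31000 nM.
Compound 3 `O=S(=O)(Nc1ccc(-c2nc3ccccc3o2)cc1)c1ccccc1Cl`, in this assay compound 3 gives > 100000 nM, which is a limit of the assay and not a number.

Compound 3 therefore stands at the weak end of the three; for it there is only a limit, (the limit of > 100000 nM in this assay, at which 1 of the 3 values shown sits), and its true value is not known. For the measured compounds named here, its relation to compound 2 is the only measured step that touches the sulfonyl side of the shared core: an at least 3.2-fold higher number from compound 2 to compound 3 (0.50 log units; beyond the scatter), a change in the aromatic ring on the sulfonyl sulfur that led to a weaker inhibitor.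

Compound 4 `O=S(=O)(Nc1ccc(-c2nc3ccccc3o2)cc1)c1ccccc1O` continues on that same ring: hydroxy in place of chloro on an aromatic carbon. Going by the values given here, no measured pair shows a hydroxy replacing a chloro, so the step from compound 3 to compound 4 has no direct precedent; the one measured change on this ring moved the number up to the limit. Starting from a limit, the step for compound 4 is expected to be small or to lead nowhere beyond the scatter: an at least 1.2-fold lower number from compound 3 to compound 4 (0.09 log units; that floor lies within the scatter). Compound 4 is thus expected to give about 80000 nM, within a range from 15000 nM to 300000 nM, with a real chance that the assay again reports only a limit.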

Compound 4, half-maximal inhibitory concentration: > 100000 nM
Compound 4: no number, only a limit (the forecaster's own chance of this, stated with the estimate: 60%); middle value at least 1.2-fold (0.09 log units) away from the limit.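

Putting hydroxy in place of chloro, on an aromatic carbon ortho to a large group, did not bring back a readable number: in this assay compound 4 gives > 100000 nM, which is a limit of the assay and not a number. The step from compound 3 to compound 4 therefore cannot be read, and neither compound can be ranked against the other, so this position has now produced a limit with two different groups, one carrying a hydrogen-bond donor and one not. Replacing 5-chlorothiophen-2-yl on the sulfonyl sulfur with 2-hydroxyphenyl gives an at least 3.2-fold higher number from compound 2 to compound 4 (0.50 log units; beyond the scatter), a floor of the same size as the one seen for 2-chlorophenyl, and the limit is now shared by compound 3 and compound 4: the limit of > 100000 nM in this assay, at which 2 of the 4 values shown sit.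

As far as these compounds go, how far compound 3 and compound 4 truly lie beyond that limit stays open, as does whether their real values differ at all. Also open, from the compounds shown here alone, is whether an amine or a carboxylic acid on this same aromatic carbon would give a number that can be read in this assay.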